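This account rests on a few compounds, and the source may have more. Where it says the series, first, only, none or still open, it means among the compounds named here.

Working notes on the series. In an ADME assay on HCT-116 cells (Homo sapiens) for cytotoxicity, read by CellTiter-Glo, with a stated time of 72 h (a lower number here means a stronger inhibitor, a higher number a weaker inhibitor), compound 1 `Cc1ccc(-c2ccccc2S(=O)(=O)N2CCC(N3CCC(C)CC3)CC2)cc1` gives > 5000 nM as a limit of the assay, not a number. Compound 2 `Cc1cc(C)c(S(=O)(=O)N2CCC(c3ccccc3)CC2)c(C)c1` gives > 5000 nM as a limit as well. Compound 3 `CC1CCN(C2CCN(S(=O)(=O)c3cccc4cnccc34)CC2)CC1` gives > 10000 nM as a limit too. Compound 1 therefore has no measured number and sits at the limit of > 5000 nM in this assay, at which 2 of the 3 values shown sit, together with compound 2, while compound 3 sits at the limit of > 10000 nM in this assay, at which 1 of the 3 values shown sits, on its own. With limits only, the three compounds cannot be ranked.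

Compound 4 `CC1CCN(C2CCN(S(=O)(=O)c3ccccc3-c3ccccc3)CC2)CC1` is still to be measured. Its difference from compound 1 is hydrogen in place of methyl on an aromatic carbon and amounts to hydrogen in place of methyl on an aromatic carbon, so that 4-methylphenyl becomes phenyl. For the measured compounds named here, no step between measured compounds is available to size this change. The expected step is a step that the limit leaves unreadable from compound 1 to compound 4 and no change beyond the scatter is anticipated in either direction. In this assay compound 4 is estimated at 6000 nM within an expected range of 2500 nM to 15000 nM. Compound 4 is expected to end up as a limit only.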

Compound 4, half-maximal inhibitory concentration: > 5000 nM
Compound 4 gave a limit, no number; the forecaster's own chance of this, stated with the estimate: 80%; the middle value lies beyond the limit too.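

Compound 4 gives a limit, not a number, in this assay: the limit of > 5000 nM in this assay, at which 3 of the 4 values shown sit. Compound 1 is also a limit, so no step can be read from their comparison. The compounds shown leave open whether any member of the series reaches a measured value in this assay.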